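From methoxy to trifluoromethyl: one compound awaits its number

The compounds below may be only part of what the source reports. "The series", "measured", "known", "first", "only" and "open" are said of these compounds alone.

In a functional assay on HeLa cells (Homo sapiens) for antiproliferative activity, read by MTT assay, with a stated time of 24 h (on this read-out higher numbers stand for weaker inhibition and lower numbers for stronger inhibition), compound 1 `Cc1ccc(-c2nn(-c3ccccc3)cc2-c2nc3ccccc3n2S(=O)(=O)c2cc(C)ccc2C)cc1` gives 370 nM and compound 2 `COc1ccc(S(=O)(=O)n2c(-c3cn(-c4ccccc4)nc3-c3ccc(F)cc3)nc3ccccc32)cc1` gives 390 nM on the same scale. These two values lie within the scatter of each other, so compound 2 stands level with compound 1 and the pair cannot be ranked.

Compound 3 `O=S(=O)(c1ccc(C(F)(F)F)cc1)n1c(-c2cn(-c3ccccc3)nc2-c2ccc(F)cc2)nc2ccccc21` has not yet been measured. It keeps the structure of compound 2 except at one place, with trifluoromethyl in place of methoxy on an aromatic carbon, para to a large group. The 4-methoxyphenyl thus becomes 4-(trifluoromethyl)phenyl trifluoromethyl in place of methoxy on an aromatic carbon in this single change.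

Within the data shown here, no measured pair in this small set shows what this change does, so there is no direct precedent. The expectation rests only on the level of compound 2 at 390 nM and on the structural change itself. In this assay the expected result is a 1.0-fold lower number from compound 2 to compound 3 (0.01 log units; within the scatter) as an estimate, with no step beyond the scatter in either direction. The estimated value for compound 3 is 380 nM with an expected range from 150 nM to 900 nM once it is measured.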

Compound 3, half-maximal inhibitory concentration: 1430 nM
Beside the measured number, compound 3's estimate is 3.8-fold (0.58 log units) below it; measured number outside the range, above it.
By their numbers in this assay, from the lowest: compounds 1 and 2 (each within the scatter of the next); then compound 3.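

Among these compounds, this is the first one-place change in the set whose effect can be read, and it shows that the group on this aromatic carbon, para to a large group, is not a neutral choice: in this assay the change gives a 3.7-fold higher number from compound 2 to compound 3 (0.56 log units; beyond the scatter). The level seen with the 4-methoxyphenyl group is therefore not kept by the 4-(trifluoromethyl)phenyl group, even though everything else in the structure stays the same, and of these two groups methoxy goes with the stronger inhibition at this position. The step is modest, but it lies beyond the scatter, unlike the gap between the two earlier values, and nothing available here accounts for the rise in the number, so it stands as an observation only.

With just two groups compared at this position, one step cannot show whether other groups would stay near the lower number or move towards the higher one, for example a hydroxyl, an amine, a carboxylic acid or a single chlorine atom on the same carbon. From the compounds shown here alone, it also remains open whether trifluoromethyl in place of methoxy would give a step of similar size on another aromatic ring of the shared core.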